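Replacing a Ring-Bearing Group with Diethylcarbamoyl on the Core

The source may report more compounds than this note shows. Statements on the series, on what has been measured and on what is new or still open speak of the compounds shown alone.

Compound 1, `C/N=C(/NC)Nc1nc(-c2ccc(OC)cc2)c(-c2ccc(OC)cc2)s1`: in a functional assay with Oryctolagus cuniculus as the target (a higher number here means a weaker inhibitor, a lower number a stronger inhibitor), compound 1 gives 970 nM.
Compound 2, `COc1ccc(-c2nc(/N=C(\N)n3ccnc3)sc2-c2ccc(OC)cc2)cc1`: in this assay compound 2 gives only a limit, > 100 nM.
Compound 3, `COc1ccc(-c2nc(CNC(=O)C3=NNC(=O)CC3)sc2-c2ccc(OC)cc2)cc1`: in this assay compound 3 gives 55 nM.

Compound 2 therefore has no number of its own, only a limit (the limit of > 100 nM in this assay, at which 1 of the 3 values shown sits), so its place among the three measured compounds cannot be fixed. Among the compounds with values here, the one step that touches it, a step that the limit leaves unreadable from compound 1 to compound 2, is for the same reason unreadable in size.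

Compound 4, `CCN(CC)C(=O)c1nc(-c2ccc(OC)cc2)c(-c2ccc(OC)cc2)s1`, is not yet measured. It differs from compound 2 in one place: a group of 7 heavy atoms (5 carbon, 1 nitrogen, 1 oxygen; no ring) in place of a group of 8 heavy atoms (4 carbon, 4 nitrogen; one five-membered aromatic ring with 2 hetero atoms), on an aromatic carbon. Within the data shown here, no measured step bears on this exchange; the only step recorded ends at the limit of compound 2 and gives no size. What remains is the spread of the numbers themselves, from compound 1 to compound 3, which shows that changes at this carbon of the shared core can move the value widely in this assay.

Compound 4 is therefore estimated at 1500 nM, with a range from 150 nM to 15000 nM. The step this estimate implies, a step that the limit leaves unreadable from compound 2 to compound 4, is expected with low confidence, and a further limit rather than a number would not surprise.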

Compound 4, half-maximal inhibitory concentration: < 10 nM
Compound 4 was reported as a limit (the forecaster's own chance of this, stated with the estimate: 30%); middle value at least 150-fold (2.17 log units) from the limit.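

In this assay, diethylcarbamoyl in place of the group with the five-membered aromatic ring gives an at least 10-fold lower number from compound 2 to compound 4 (1.00 log units; beyond the scatter), and in place of the group with no ring it gives an at least 97-fold lower number from compound 1 to compound 4 (1.98 log units; beyond the scatter). Compound 4 has only a limit in this assay, not a number of its own: the limit of < 10 nM in this assay, at which 1 of the 4 values shown sits. So on this aromatic carbon, which lies next to the ring nitrogen and the ring sulfur, neither a second ring nor a hydrogen-bond donor in the group is needed for a low number, as diethylcarbamoyl has no ring and 0 hydrogen-bond donors, yet it ends far lower than the two groups it is compared with.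

The compounds shown do not separate the part played by the carbonyl from that of the two ethyl groups, which a dimethylamide, a pyrrolidine amide or a plain carboxylic acid on this carbon could begin to do. Going by these compounds, how far the true value of compound 4 lies past its limit also stays open, so the full size of both steps remains unknown.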